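The source may report more compounds than this note shows. Statements on the series, on what has been measured and on what is new or still open speak of the compounds shown alone.

In an ADME assay on S9 fraction from liver (Homo sapiens) for metabolic stability, using NADPH, tested at 0.1 uM (a lower number here means that the compound disappears faster, a higher number that the compound lasts longer), compound 1 (`FC(F)(F)c1cc(Oc2ccc(COc3ccn4c(-c5cncnc5)cnc4n3)cc2)ccc1Cl`) gives 1.93 h and compound 2 (`Cn1cc(-c2cnc3nc(OCc4ccc(Oc5ccc(Cl)c(C(F)(F)F)c5)cc4)ccn23)cn1`) gives 3 h with the two values within the scatter of each other. Compound 3 (`N#Cc1cc(COc2ccn3c(-c4cncnc4)cnc3n2)ccc1Oc1ccc(Cl)c(C(F)(F)F)c1`) differs from compound 1 by cyano in place of hydrogen on an aromatic carbon with cyano in place of hydrogen on an aromatic carbon, ortho to a 4-chloro-3-(trifluoromethyl)phenoxy group. Going by the values given here, the only measured step, a 1.6-fold higher number from compound 1 to compound 2 (0.19 log units; within the scatter), exchanges a different group and stays within the scatter. Among the compounds with values here, no measured step covers cyano, so nothing beyond the scatter is expected in this assay in either direction. The estimate means a 1.1-fold higher number from compound 1 to compound 3 (0.06 log units; within the scatter) and is expected to stay within the scatter. For compound 3 the estimated half-life is 2.2 h with an expected range from 1 h to 5 h in repeat measurements.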

Compound 3, half-life: 1.77 h
Beside the measured number, compound 3's estimate is 1.2-fold (0.09 log units) above it, within the range that was stated.
By their numbers in this assay, from the lowest: compounds 3, 1 and 2 (each within the scatter of the next).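

In this assay, cyano in place of hydrogen on an aromatic carbon, ortho to a 4-chloro-3-(trifluoromethyl)phenoxy group, gives a 1.1-fold lower number from compound 1 to compound 3 (0.04 log units; within the scatter). At this position, the ring of carbon only thus takes a nitrile with the half-life staying within the scatter, whereas the earlier step covered only the exchange of pyrimidin-5-yl. No supporting measurement bears on this result. On these data alone, whether an amine or a carboxylic acid at this position would also stay within the scatter remains open. Also open, as far as these compounds go, is whether cyano would behave the same way with the 1-methyl-1H-pyrazol-4-yl group of compound 2.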